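The source may hold more compounds than are shown below. What is called first, only, known or untested is meant among the compounds shown, and "the series" means these compounds.

Working notes on the series. Compound 1 `Cc1cc(Br)ccc1C(=O)Nc1ccccn1` reads > 100 ug/mL in a physicochemical assay for solubility, read by nephelometry, measured as kinetic solubility, at pH 6.5, tested at 10 mg/mL (on this read-out lower numbers stand for lower solubility and higher numbers for higher solubility), as a limit of the assay, not a number. Compound 2 `Cc1ccccc1C(=O)Nc1cccc(F)n1` reads > 100 ug/mL in this assay as a limit too. Among the measured compounds shown here, compound 3 `COc1ccc(NC(=O)c2ccccc2C)nc1` reads 12.5 ug/mL and is the only compound here with an actual number. Compound 4 `Cc1ccccc1C(=O)Nc1ccc(C#N)cn1` is still unmeasured. The change from compound 3 to compound 4 is cyano in place of methoxy on an aromatic carbon, two atoms from the ring nitrogen and para to a large group (cyano in place of methoxy on an aromatic carbon). For the measured compounds named here, no measured pair in the set differs in one place only, so the size of this change has no direct precedent. No step beyond the usual scatter is expected in this assay in either direction, with compound 3 at 12.5 ug/mL as the only numerical anchor. The expected range is drawn wider on the upward side, given the limit of > 100 ug/mL in this assay, at which 2 of the 3 values shown sit, in this small set. The expected step is a 1.2-fold higher number from compound 3 to compound 4 (0.08 log units; within the scatter) as an estimate only. For compound 4 the estimated value is 15 ug/mL with an expected range of 5 ug/mL to 60 ug/mL on this read-out.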

Compound 4, solubility: 6.3 ug/mL
Compound 4: middle estimate off by 2.4-fold (0.38 log units), on the high side; the measured number falls inside the stated range.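

Among the compounds shown here, the step of a 2.0-fold lower number from compound 3 to compound 4 (0.30 log units; within the scatter) in this assay gives the first direct reading of a single change in this set: cyano in place of methoxy on an aromatic carbon, two atoms from the ring nitrogen and para to a large group. On this read-out, the two groups, each with 2 heavy atoms and 1 hydrogen-bond acceptor, cannot be told apart at this position. For the compounds shown here, compound 3 and compound 4 are also the only compounds here with actual numbers, as the other values are limits of the assay: the limit of > 100 ug/mL in this assay, at which 2 of the 4 values shown sit.

As far as these compounds go, whether an amine or a carboxylic acid at this position would read the same remains open. One pair also cannot show whether this change would read alike on a core carrying other substituents.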